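Pentylseleno to methylseleno on a benzylamino quinazoline core

The compounds below may be only part of what the source reports. "The series", "measured", "known", "first", "only" and "open" are said of these compounds alone.

Measured so far:
Compound 1 `COc1ccc(CNc2nc([Se]C)nc3ccccc23)cc1`: 73600 nM
Compound 2 `CCCCC[Se]c1nc(NCc2ccc(SC)cc2)c2ccccc2n1`: 83600 nM
Compound 3 `CCCCC[Se]c1nc(NCc2ccccc2)c2ccccc2n1`: 72700 nM

In a functional assay on HT-29 cells (Homo sapiens) for cytotoxicity, read by MTT assay, with a stated time of 72 h (a lower number here means a stronger inhibitor of growth, a higher number a weaker inhibitor of growth), compound 3 gives 72700 nM, a number that sits with those of compound 1 and compound 2, within the scatter of each. For the measured compounds named here, the one measured step, a 1.1-fold lower number from compound 2 to compound 3 (0.06 log units; within the scatter), is itself within the scatter. Compound 4 `C[Se]c1nc(NCc2ccccc2)c2ccccc2n1` is compound 3 with hydrogen in place of butyl on a saturated chain carbon bound to a selenium atom. Going by the values given here, no measured step bears directly on this change; compound 1, which also carries the methyl on selenium, gives a number close to that of compound 3. Compound 4 is therefore expected to show no step beyond the scatter, a 1.0-fold higher number from compound 3 to compound 4 (0.00 log units; within the scatter). The estimate for compound 4 in this assay is 73000 nM, with a range from 35000 nM to 150000 nM.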

Compound 4, concentration for 50% growth inhibition: 42800 nM
The estimate for compound 4 lay 1.7-fold (0.23 log units) above the measured number; low and high end bracket the measured number.
By their numbers in this assay, from the lowest: compounds 4, 3, 1 and 2 (each within the scatter of the next).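

In this assay, for the compounds shown here, the change from pentyl to methyl is read directly for the first time, as a 1.7-fold lower number from compound 3 to compound 4 (0.23 log units; within the scatter) and so without a shift beyond the scatter at this place. With the methyl already in place, a 1.7-fold lower number from compound 1 to compound 4 (0.24 log units; within the scatter) shows that hydrogen in place of methoxy on an aromatic carbon also stays within the scatter. Nothing measured here accounts for either step.

The compounds shown leave open whether a longer chain such as decyl, or a chain carrying an amine or a carboxylic acid, would move the number beyond the scatter.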